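The source may report more compounds than this note shows. Statements on the series, on what has been measured and on what is new or still open speak of the compounds shown alone.

Measured compounds:
Compound 1, `Cc1ccc(N2CCN(CCNC(=O)c3cccnc3)CC2)c(C)c1`, gives 1150 nM in a functional assay for antagonist activity at Adrenergic receptor alpha-1 (Rattus norvegicus); on this read-out lower numbers stand for tighter binding and higher numbers for weaker binding.
Compound 2, `COc1ccc(Cl)cc1N1CCN(CCNC(=O)c2cc3ccccc3o2)CC1`, gives 2340 nM in this assay.
Compound 3, `Cc1ccc(N2CCN(CCNC(=O)c3ccco3)CC2)c(C)c1`, gives 19.1 nM in this assay.

Compound 3 has the lowest number of the three in this assay; compound 1 lies a good deal higher, and compound 2 higher still, both beyond the scatter. Among the measured compounds shown here, the only single-point step among the measured compounds is a 60-fold lower number from compound 1 to compound 3 (1.78 log units; beyond the scatter), which concerns the group on the carbonyl carbon.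

Compound 4, `Cc1ccc(N2CCN(CCNC(=O)c3cc4ccccc4o3)CC2)c(C)c1`, is not yet measured. It differs from compound 3 in one place: 1-benzofuran-2-yl in place of furan-2-yl on a carbonyl carbon. For the measured compounds named here, no measured step follows exactly this change. Compound 2 carries the same 1-benzofuran-2-yl group on a different core and gives a high number in this assay, but it differs from compound 3 in two places, so its weight here is limited. Going by the values given here, the one measured step shows that the group on the carbonyl carbon can move the number strongly. Compound 4 is therefore expected to give 100 nM in this assay, between 20 nM and 600 nM. That estimate means a step of a 5.2-fold higher number from compound 3 to compound 4 (0.72 log units; beyond the scatter), expected to be a moderate weakening.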

Compound 4, dissociation constant: 43.7 nM
Compound 4: middle estimate off by 2.3-fold (0.36 log units), on the high side, and the stated range covers the measured number.
By their numbers in this assay, from the lowest: compound 3; then compound 4; then compound 1; then compound 2.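

In this assay, compound 4 gives the shared core a third group on the carbonyl carbon, and a 2.3-fold higher number from compound 3 to compound 4 (0.36 log units; beyond the scatter) shows that extending furan-2-yl to 1-benzofuran-2-yl costs far less than the change to pyridin-3-yl. Even so, a 26-fold lower number from compound 1 to compound 4 (1.42 log units; beyond the scatter) places 1-benzofuran-2-yl well on the low side of pyridin-3-yl at this position. With 1-benzofuran-2-yl held fixed, 2,4-dimethylphenyl in place of 5-chloro-2-methoxyphenyl on an amine nitrogen in a ring gives a 54-fold lower number from compound 2 to compound 4 (1.73 log units; beyond the scatter), so the high number of compound 2 goes with that aryl group rather than with 1-benzofuran-2-yl.

Nothing available bears on why these steps have the sizes they do. On these data alone, it remains open whether a thiophen-2-yl group on the carbonyl carbon would fall with furan-2-yl or with pyridin-3-yl, and whether 5-chloro-2-methoxyphenyl would cost as much alongside furan-2-yl.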